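This account rests on a few compounds, and the source may have more. Where it says the series, first, only, none or still open, it means among the compounds named here.

Measured so far:
compound 1 `CN1C(=S)[C@@H](NC(=O)c2n[nH]c(Cc3ccccc3)n2)COc2ccccc21`: > 50000 nM; > 50000 nM (2 entries)
compound 2 `O=C(N[C@H]1COc2ccccc2NC1=S)c1n[nH]c(Cc2ccccc2)n1`: > 50000 nM

In an ADME assay on HT-29 cells (Homo sapiens) for cytotoxicity, read by luminescence and CellTiter-Glo, with a stated time of 10 h (a higher number here means that more compound is tolerated, a lower number that less compound is tolerated), compound 2 gives > 50000 nM, which is a limit of the assay and not a number. Compound 1 gives > 50000 nM; > 50000 nM (2 entries), again a limit. Compound 3 `CCN1C(=S)[C@@H](NC(=O)c2n[nH]c(Cc3ccccc3)n2)COc2ccccc21` differs from compound 2 by ethyl in place of hydrogen on an amide-type nitrogen in a ring, with ethyl in place of hydrogen on an amide-type nitrogen in a ring. The expectation for this change rests only on compound 2 with its limit of > 50000 nM. The expected step is a number no higher from compound 2 to compound 3 (the limit leaves the size open), none beyond the scatter. For compound 3 the estimated value is 50000 nM, with an expected range of 25000 nM to 100000 nM.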

Compound 3, half-maximal cytotoxic concentration: > 50000 nM
Compound 3: only a limit was reported (the forecaster's own chance of this, stated with the estimate: 85%); the middle value sits exactly at the limit.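

For the compounds shown here, no step from compound 2 to compound 3 can be read in this assay because both results are limits of the assay: the limit of > 50000 nM in this assay, at which 2 of the 3 values shown sit. As far as these compounds go, whether ethyl in place of hydrogen on an amide-type nitrogen in a ring changes the tolerated concentration at all remains open.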